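Swapping carboxy side chains on the amide-type nitrogen

This account rests on a few compounds, and the source may have more. Where it says the series, first, only, none or still open, it means among the compounds named here.

In a functional assay on MCF7 cells (Homo sapiens) for antiproliferative activity, read by MTT assay, with a stated time of 24 h (on this read-out higher numbers stand for weaker inhibition and lower numbers for stronger inhibition), compound 3 `CCn1c(C(=O)NC2(C(=O)O)CC2)ccc1C(CC)(CC)c1ccc(OCS(=O)(=O)c2ccccc2)c(C)c1` gives 41200 nM as the highest of the two actual numbers. Compound 2 `CCN(CC)CCNC(=O)c1ccc(C(CC)(CC)c2ccc(OCS(=O)(=O)c3ccccc3)c(C)c2)n1CC` gives 4680 nM in this assay as the other number. Compound 1 `CCn1c(C(=O)N[C@H](C)C(=O)OC)ccc1C(CC)(CC)c1ccc(OCS(=O)(=O)c2ccccc2)c(C)c1` reads > 50000 nM and this is a limit, not a number.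

Compound 4 `CCn1c(C(=O)N[C@@H](C(=O)O)C(C)C)ccc1C(CC)(CC)c1ccc(OCS(=O)(=O)c2ccccc2)c(C)c1` differs from compound 3 as follows: 1-carboxy-2-methylpropyl in place of 1-carboxycyclopropyl on an amide-type nitrogen with the three-membered ring lost and a defined stereocentre gained.

Two steps beyond the scatter involve 2-(diethylamino)ethyl: an at least 10-fold lower number from compound 1 to compound 2 (1.02 log units; beyond the scatter) and an 8.8-fold higher number from compound 2 to compound 3 (0.94 log units; beyond the scatter) on this nitrogen. Compound 4 lacks that group. The nearer comparison, an at least 1.2-fold lower number from compound 1 to compound 3 (0.08 log units; that floor lies within the scatter) as a step, has a floor within the scatter.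

No step beyond the scatter is expected, and the expected step is a 1.0-fold higher number from compound 3 to compound 4 (0.01 log units; within the scatter) in this assay as an estimate. The estimate for compound 4 is 42000 nM (expected range 20000 nM to 80000 nM).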

Compound 4, half-maximal inhibitory concentration: 44700 nM
The estimate for compound 4 lay 1.1-fold (0.03 log units) below the measured number; measured number inside the range.
By their numbers in this assay, from the lowest: compound 2; then compounds 3 and 4 (each within the scatter of the next). At a limit, above all of these: compound 1.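

In this assay, 1-carboxy-2-methylpropyl in place of 1-carboxycyclopropyl on this amide-type nitrogen gives a 1.1-fold higher number from compound 3 to compound 4 (0.04 log units; within the scatter). A second carboxylic acid side chain also stands well apart from the 2-(diethylamino)ethyl side chain: a 9.6-fold higher number from compound 2 to compound 4 (0.98 log units; beyond the scatter). Compound 1 sits at a limit, not a number, and only a floor can be given for its step: an at least 1.1-fold lower number from compound 1 to compound 4 (0.04 log units; that floor lies within the scatter). The limit is this: the limit of > 50000 nM in this assay, at which 1 of the 4 values shown sits.

Open, as far as these compounds go, is how a morpholine in place of the diethylamino group of compound 2 would read. Also open, from the compounds shown here alone, is the effect of a longer chain between that amine and the amide-type nitrogen.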